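The source may hold more compounds than are shown below. What is called first, only, known or untested is meant among the compounds shown, and "the series" means these compounds.

Of the compounds shown here, three have been measured in a physicochemical assay for solubility, at pH 6.8; a lower number here means a less soluble compound, a higher number a more soluble compound. Compound 1 `Cc1c(COc2ccnc(OCC3CCOCC3)c2)[nH]c2ccccc2c1=O` gives 22000 nM. Compound 2 `CCCCOc1cccc(OCc2[nH]c3ccccc3c(=O)c2C)c1` gives < 1000 nM, which is a limit of the assay and not a number. Compound 3 `Cc1c(COc2cccc(OCC3CCOCC3)c2)[nH]c2ccc(C(=O)O)cc2c1=O` gives >= 100000 nM, which is also a limit. This places compound 3 at the upper end of the readings so far. Compound 4 `COc1ccc2[nH]c(COc3cccc(OCC4CCOCC4)c3)c(C)c(=O)c2c1` has methoxy in place of carboxy on an aromatic carbon. Within the data shown here, no measured pair shows this change alone, so its size must be judged. Only compound 3 carries carboxy, and compound 1, without it, gives 22000 nM. A large fall beyond the scatter is therefore expected, and the estimated step is an at least 50-fold lower number from compound 3 to compound 4 (1.69 log units; beyond the scatter). For compound 4 the expected value is 2000 nM, within an estimated range of 500 nM to 8000 nM.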

Compound 4, solubility: < 1000 nM
Compound 4: no number, only a limit; the forecaster's own chance of this, stated with the estimate: 40%; at least 2.0-fold (0.30 log units) between middle value and limit.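

In this assay, among these compounds, this is the first single change that can be read: methoxy in place of carboxy on an aromatic carbon gives an at least 100-fold lower number from compound 3 to compound 4 (2.00 log units; beyond the scatter). Compound 3 stands at one limit of the assay: the limit of >= 100000 nM in this assay, at which 1 of the 4 values shown sits. Compound 4 stands at the other: the limit of < 1000 nM in this assay, at which 2 of the 4 values shown sit.

From the compounds shown here alone, neither compound has an exact number, so the full size of this step stays open. Also open, going by these compounds, is how an amine or a hydroxyl group on this same aromatic carbon would read, as a value between these two limits or at one of them.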